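Swapping fluoro for bromo: what to expect for compound 4

The source may hold more compounds than are shown below. What is called first, only, known or untested is meant among the compounds shown, and "the series" means these compounds.

Three compounds have been measured in a functional assay on HepG2 cells (Homo sapiens) for inhibition, read by MTT assay; on this read-out lower numbers stand for stronger inhibition and higher numbers for weaker inhibition:
- compound 1 `COc1cc2ncnc(Nc3ccc(NC(=O)c4cccc(C)c4)cc3)c2cc1OC`: 7500 nM
- compound 2 `COc1cc2ncnc(Nc3ccc(NC(=O)c4ccc(C)cc4)cc3)c2cc1OC`: 25000 nM
- compound 3 `COc1cc2ncnc(Nc3ccc(NC(=O)c4ccc(F)cc4)cc3)c2cc1OC`: 15000 nM

On these numbers, compound 3 cannot be told apart from either of the others, as the gaps are a 2.0-fold higher number from compound 1 to compound 3 (0.30 log units; within the scatter) and a 1.7-fold lower number from compound 2 to compound 3 (0.22 log units; within the scatter). The next compound is compound 4 `COc1cc2ncnc(Nc3ccc(NC(=O)c4ccc(Br)cc4)cc3)c2cc1OC`, which has bromo in place of fluoro on an aromatic carbon, para to a large group: bromo in place of fluoro on an aromatic carbon.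

Within the data shown here, no bromo compound has been measured yet. The closest guide is the second of those gaps, a swap of one small group for another on an aromatic carbon, and it stayed within the scatter. Among the measured compounds shown here, the largest step so far, a 3.3-fold higher number from compound 1 to compound 2 (0.52 log units; beyond the scatter), exchanges 3-methylphenyl for 4-methylphenyl, so it bears less directly on this change. In this assay, no change beyond the scatter is therefore expected. The expected step is a 1.1-fold higher number from compound 3 to compound 4 (0.05 log units; within the scatter). The estimate for compound 4 is 17000 nM, with an expected range of 8000 nM to 36000 nM.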

Compound 4, half-maximal inhibitory concentration: 35000 nM
Estimate against measurement, compound 4: 2.1-fold (0.31 log units) below; the measured number falls inside the stated range.
By their numbers in this assay, from the lowest: compounds 1, 3, 2 and 4 (each within the scatter of the next, the first and the last beyond it).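

In this assay, among these compounds, exchanging fluoro for bromo gives a 2.3-fold higher number from compound 3 to compound 4 (0.37 log units; beyond the scatter) and is the first swap of one group for another at this carbon, para to a large group, to go beyond the scatter. Methyl sits unresolved between the two halogens: a 1.4-fold higher number from compound 2 to compound 4 (0.15 log units; within the scatter) joins the earlier finding that compound 2 and compound 3 cannot be told apart, so fluoro and bromo separate while methyl cannot be distinguished from either. The widest step, a 4.7-fold higher number from compound 1 to compound 4 (0.67 log units; beyond the scatter) and also the first to span all four compounds, changes both the group and where it sits on the ring, and no measurement here explains any of these steps.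

Going by these compounds, how an amine, a carboxylic acid or a longer chain would read at this carbon remains open. So does whether fluoro or bromo, placed where the methyl of compound 1 sits, would follow compound 1.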